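The source may hold more compounds than are shown below. What is called first, only, known or untested is meant among the compounds shown, and "the series" means these compounds.

Four close relatives share one core. Compound 1 `CCC(C)CNc1cc(-c2[nH]c(SC)nc2-c2ccc(F)cc2)ccn1` carries a 2-methylbutyl chain on its amine, compound 2 `CSc1nc(-c2ccc(F)cc2)c(-c2ccnc(NC3CCc4ccccc43)c2)[nH]1` a bicyclic group, compound 3 `CSc1nc(-c2ccc(F)cc2)c(-c2ccnc(N[C@H]3CC[C@H](C)CC3)c2)[nH]1` a 4-methylcyclohexyl group, and compound 4 `CCC(Nc1cc(-c2[nH]c(SC)nc2-c2ccc(F)cc2)ccn1)c1ccccc1` a 1-phenylpropyl group. In a functional assay on blood (Homo sapiens) for inhibition (a lower number here means a stronger inhibitor, a higher number a weaker inhibitor), compound 1 gives 2760 nM. For compound 2 this assay gives "not determined" (no result reported). Going by the values given here, for compound 3 this assay likewise gives "not determined" (no result reported), so compound 3 stands without a number, and no measured step leads to compound 4. The change from compound 3 to compound 4 1-phenylpropyl in place of 4-methylcyclohexyl on a nitrogen on an aromatic ring is the only thing that can be said of the pair. The value of compound 1 is the sole anchor, and compound 4 is expected to land near it, at roughly 1800 nM, within 350 nM to 9000 nM.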

Compound 4, half-maximal inhibitory concentration: 7640 nM
Estimate against measurement, compound 4: 4.2-fold (0.63 log units) below; low and high end bracket the measured number.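

In this assay, 1-phenylpropyl in place of 2-methylbutyl on the nitrogen gives a 2.8-fold higher number from compound 1 to compound 4 (0.44 log units; beyond the scatter), a modest weakening beyond the usual scatter. This first measured step shows that the group at this position affects inhibition, and that this ring-bearing group is weaker than the open chain of compound 1. Nothing available explains the difference.

Steps involving compound 2 or compound 3 cannot be read, as neither has a number. From the compounds shown here alone, whether a hydroxyl or amine on the chain would restore strength remains open.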